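This account rests on a few compounds, and the source may have more. Where it says the series, first, only, none or still open, it means among the compounds named here.

Of the compounds shown here, two of the same core have been tested so far. Compound 1 `Cc1nc(NC(=O)c2ccccc2)sc1C(=O)/C=C/c1ccc(Cl)cc1` and compound 2 `Cc1nc(NC(=O)c2ccccc2)sc1C(=O)/C=C/c1cccc([N+](=O)[O-])c1` differ only in the aromatic ring at the end of the double-bonded chain. In an assay for inhibition of Polyunsaturated fatty acid 5-lipoxygenase (Homo sapiens), read by spectrophotometry, tested at 10 uM, in the presence of a further agent that is not named here (a higher number here means more inhibition at the concentration tested (going by the name of the read-out), a lower number less inhibition), compound 1 gives 63.7%, while compound 2 gives 98%. Among the measured compounds shown here, the single measured step, a number 34.3 percentage points higher from compound 1 to compound 2 (beyond the scatter), is large and goes well beyond the usual scatter. For the measured compounds named here, on these numbers compound 2 stands highest of the two, with compound 1 as its only neighbour and clearly lower.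

Compound 3 `COc1ccc(/C=C/C(=O)c2sc(NC(=O)c3ccccc3)nc2C)cc1` is the next compound and is not yet measured. It differs from compound 2 in one place: 4-methoxyphenyl in place of 3-nitrophenyl on a double-bonded chain carbon bound to a double-bonded chain carbon. Going by the values given here, the only step that bears on this change is the one from compound 1 to compound 2, where a different ring at the same place moved the read-out by a large amount. A third ring at that place is therefore expected to move the read-out again, most likely downward toward the level of compound 1, though its size is uncertain. Compound 3 is expected to give about 55%, within 30% to 85%. That would correspond to an expected step of a number 43 percentage points lower from compound 2 to compound 3 (beyond the scatter).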

Compound 3, a percentage reported as inhibition, at one concentration (the size of the read-out at that concentration, not a potency): 58.8%
Estimate against measurement, compound 3: 3.8 percentage points below; the measured number falls inside the stated range.
By their numbers in this assay, from the lowest: compounds 3 and 1 (each within the scatter of the next); then compound 2.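

In this assay, replacing 3-nitrophenyl with 4-methoxyphenyl gives a number 39.2 percentage points lower from compound 2 to compound 3 (beyond the scatter) and so a second large step at this place on the chain, which shows that the read-out here depends strongly on the ring. Methoxy in place of chloro on an aromatic carbon gives a number 4.9 percentage points lower from compound 1 to compound 3 (within the scatter) and so leaves these two rings indistinguishable in this test, with 3-nitrophenyl the only one of the three rings that stands apart from the others. No measurement is available that would explain these differences.

The compounds shown leave open whether the high reading of compound 2 depends on the nitro group itself or on where it sits on the ring, since the ring in compound 2 differs from the other two rings in both respects. They also leave open what the read-out would be with other groups on this ring, such as an amine or a carboxylic acid, and so whether any other group can match 3-nitrophenyl.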